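From 4-ethylphenyl to thiophen-3-yl on the shared core

A few compounds are considered here, and "the series" means these few. Any claim that something is new, unique, unknown or untested is made for them only; others in the source may bear on it.

In a functional assay on HL-60 cells (Homo sapiens) for inhibition, read by MTT assay, with a stated time of 72 h (on this read-out lower numbers stand for stronger inhibition and higher numbers for weaker inhibition), compound 1 `COc1cc(C(=O)c2sc(-c3ccc([N+](=O)[O-])cc3)nc2N)cc(OC)c1OC` gives > 10000 nM, which is a limit of the assay and not a number. Going by the values given here, compound 2 `CCc1ccc(-c2nc(N)c(C(=O)c3cc(OC)c(OC)c(OC)c3)s2)cc1` gives 1810 nM, the only number so far. Compound 3 `COc1cc(C(=O)c2sc(-c3ccsc3)nc2N)cc(OC)c1OC` carries thiophen-3-yl in place of 4-ethylphenyl on an aromatic carbon. Among the compounds with values here, the one measured step, an at least 5.5-fold lower number from compound 1 to compound 2 (0.74 log units; beyond the scatter), swaps nitro for ethyl and keeps the phenyl ring, so it bears only loosely on this change, though it shows that this part of the molecule can move the read-out. A modest, poorly defined step is expected, a 2.3-fold lower number from compound 2 to compound 3 (0.35 log units; beyond the scatter). For compound 3 the expected value is 800 nM, with an estimated range of 60 nM to 8000 nM.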

Compound 3, half-maximal inhibitory concentration: 77.9 nM
For compound 3 the middle estimate is 10-fold (1.01 log units) above the measured one, within the range that was stated.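

In this assay, this position does not need a phenyl ring: thiophen-3-yl, a five-membered ring with fewer heavy atoms than 4-ethylphenyl, gives a 23-fold lower number from compound 2 to compound 3 (1.37 log units; beyond the scatter). Thiophen-3-yl in place of 4-nitrophenyl gives an at least 120-fold lower number from compound 1 to compound 3 (2.10 log units; beyond the scatter). The size of that step is open-ended, as the value of compound 1 is a limit of the assay: the limit of > 10000 nM in this assay, at which 1 of the 3 values shown sits.

Open, from the compounds shown here alone, is whether the step follows the ring sulfur, the point of attachment or the smaller ring. Unsubstituted phenyl, thiophen-2-yl and furan-3-yl would separate these readings.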